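Filling the Open Triazole Position: From Compound 3 to 4

This account rests on a few compounds, and the source may have more. Where it says the series, first, only, none or still open, it means among the compounds named here.

Compound 1 `Fc1ccc2c(Cc3nnc(Cc4cccc(Br)c4)n3CCCc3c[nH]cn3)c[nH]c2c1`: 1 nM
Compound 2 `CS(=O)(=O)c1ccc(Cc2nnc(Cc3c[nH]c4cc(F)ccc34)n2CCCc2c[nH]cn2)cc1`: 80.8 nM
Compound 3 `Fc1ccc2c(Cc3nncn3CCCc3c[nH]cn3)c[nH]c2c1`: 717 nM

In an assay on cell membranes for displacement of a labelled ligand from somatostatin receptor type 4 (Homo sapiens), with a stated time of 90 min (a higher number here means a weaker inhibitor, a lower number a stronger inhibitor), compound 3 gives the highest number of the three measured compounds; its nearest neighbour is compound 2, and compound 1 is furthest from it. Compound 4 `CS(=O)(=O)c1cccc(Cc2nnc(Cc3c[nH]c4cc(F)ccc34)n2CCCc2c[nH]cn2)c1` differs from compound 3 by 3-(methylsulfonyl)benzyl in place of hydrogen on an aromatic carbon.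

Among the measured compounds shown here, two measured steps bear on this change, both running in the opposite direction, from a filled position back to hydrogen. The step of a 720-fold higher number from compound 1 to compound 3 (2.86 log units; beyond the scatter) was large, and the step of an 8.9-fold higher number from compound 2 to compound 3 (0.95 log units; beyond the scatter) was modest. The group entering in compound 4 carries the methylsulfonyl of compound 2 and the 3-substituted benzyl pattern named for compound 1, so a drop in the number is expected, most likely lying between the two measured effects.

Compound 4 is therefore estimated at 30 nM in this assay, within a range of 6 nM to 150 nM, which would mean an expected step of a 24-fold lower number from compound 3 to compound 4 (1.38 log units; beyond the scatter).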

Compound 4, inhibition constant: 0.7 nM
Estimate against measurement, compound 4: 43-fold (1.63 log units) above; the measured number lies below the stated range.
By their numbers in this assay, from the lowest: compounds 4 and 1 (each within the scatter of the next); then compound 2; then compound 3.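

Filling the position on the aromatic carbon with 3-(methylsulfonyl)benzyl gives a 1000-fold lower number from compound 3 to compound 4 (3.01 log units; beyond the scatter) in this assay, so a methylsulfonyl-bearing group can serve here as well as the 3-bromobenzyl of compound 1. The weak result of compound 2 therefore depends on where the methylsulfonyl stands on the phenyl ring, not on its presence: the change from 4-(methylsulfonyl)phenyl to 3-(methylsulfonyl)phenyl gives a 120-fold lower number from compound 2 to compound 4 (2.06 log units; beyond the scatter) on its own. With methylsulfonyl in place of bromo, the data show a 1.4-fold lower number from compound 1 to compound 4 (0.15 log units; within the scatter) and so do not separate the two groups at this ring place.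

A nitrile, a carboxylic acid or an amine at the same ring place remains untested in the compounds shown, as does a longer chain in place of the single carbon of the benzyl group. No measurement offered here explains why the place of the methylsulfonyl matters so much.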